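This account rests on a few compounds, and the source may have more. Where it says the series, first, only, none or still open, it means among the compounds named here.

Going by the values given here, compound 1 `c1cc(-c2ccn[nH]2)c2c(c1)C(c1ncc[nH]1)CC2` is the one compound in this set that yields a single number in a functional assay on CHO cells for agonist activity at Alpha-1B adrenergic receptor (Homo sapiens), read by FLIPR and calcium flux; on this read-out lower numbers stand for an effect already at smaller amounts and higher numbers for an effect only at larger amounts of compound; compound 1 gives 600 nM. Compound 2 `CCS(=O)(=O)Nc1cccc(Cc2c[nH]cn2)c1` reaches only the limit of this assay, with > 10000 nM. Compound 3 `CS(=O)(=O)Nc1cccc2c1CCCC2c1ncc[nH]1` likewise reaches only the limit of this assay, with > 10000 nM; > 10000 nM; > 10000 nM (3 entries) in each of three repeats. Among the compounds with values here, no step between measured compounds connects compound 1 with compound 2 or compound 3; their values show no more than that compound 1 gives a measurable number where the other two do not.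

Compound 4 `Cn1cc(-c2cccc3c2CCC3c2ncc[nH]2)cn1` has not yet been measured in this assay. It differs from compound 1 by 1-methyl-1H-pyrazol-4-yl in place of 1H-pyrazol-5-yl on an aromatic carbon. Within the data shown here, no measured pair in this set shows this kind of change, so the size of the step has to be estimated rather than read from data. The step from compound 1 to compound 4 is expected to be a 4.2-fold higher number from compound 1 to compound 4 (0.62 log units; beyond the scatter), toward an effect only at larger amounts, and probably beyond the usual scatter. Compound 4 is therefore estimated at 2500 nM in this assay, within a range from 500 nM to 10000 nM, with a real chance that the assay reports only a limit.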

Compound 4, half-maximal effective concentration: > 10000 nM
Compound 4 was reported as a limit (the forecaster's own chance of this, stated with the estimate: 30%); middle value at least 4.0-fold (0.60 log units) from the limit.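

Going by these compounds alone, replacing 1H-pyrazol-5-yl with 1-methyl-1H-pyrazol-4-yl on an aromatic carbon gives an at least 16-fold higher number from compound 1 to compound 4 (1.22 log units; beyond the scatter) in this assay, the first single change on the core of compound 1 in this set. Within the data shown here, it shows that the one single number recorded here depends on the group at this place, and that a five-membered aromatic ring with two hetero atoms does not by itself preserve it. The value of compound 4 is a limit, so the step gives only a minimum and its true size remains unknown, and compound 4 now sits with the other compound that stops at the same limit: the limit of > 10000 nM in this assay, at which 2 of the 4 values shown sit.

The change alters the methyl on nitrogen and the point of attachment together, along with the count of hydrogen-bond donors, so the compounds shown cannot tell which of these goes with the loss of a measurable number, a question that 1H-pyrazol-4-yl on the same core would help to separate. From the compounds shown here alone, how a quite different group at this place, such as an amine or a carboxylic acid, would read in this assay also remains open.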